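This account rests on a few compounds, and the source may have more. Where it says the series, first, only, none or still open, it means among the compounds named here.

Measured compounds:

compound 1 `CC(C)C[C@H](N)c1cc(C(F)(F)F)ccc1N1CCN(C(=O)COc2ccc3ccccc3c2)CC1` — in an assay on HEK293 cells for displacement of a labelled ligand from Melanocortin receptor 4 (Homo sapiens) (a higher number here means a weaker inhibitor, a lower number a stronger inhibitor), compound 1 gives 2000 nM
compound 2 `CC(C)C[C@H](N)c1cc(C(F)(F)F)ccc1N1CCN(C(=O)C(C)Cc2ccc(Cl)c(Cl)c2)CC1` — in this assay compound 2 gives 120 nM; 1600 nM (2 entries)
compound 3 `CC(C)C[C@H](N)c1cc(C(F)(F)F)ccc1N1CCN(C(=O)COc2cccc(Cl)c2Cl)CC1` — in this assay compound 3 gives 2500 nM

All three share the same core and differ only in the group attached to the carbonyl carbon of the amide. Compound 3 and compound 1 sit close together: the change a 1.3-fold higher number from compound 1 to compound 3 (0.10 log units; within the scatter) lies within the usual scatter, so the two cannot be told apart. Compound 2, which carries no oxygen between the carbonyl and the aromatic ring, is harder to place because the several entries of compound 2 in this assay, 120 nM; 1600 nM (2 entries) disagree widely with each other.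

Compound 4 `COc1ccc(CC(C)C(=O)N2CCN(c3ccc(C(F)(F)F)cc3[C@@H](N)CC(C)C)CC2)cc1` is the next compound to be measured. It differs from compound 3 as follows: 1-(4-methoxybenzyl)ethyl in place of (2,3-dichlorophenoxy)methyl on a carbonyl carbon. This change removes the oxygen link and both chlorines and puts a methoxy-bearing benzyl group on a branched carbon next to the carbonyl, a pattern close to that of compound 2. Going by the values given here, the only measured step, from compound 1 to compound 3, swapped one aromatic group for another on the oxygen and stayed within the scatter, so it gives little guidance here. Compound 2 offers the closer comparison, and its two entries span a wide interval.

Compound 4 is therefore expected to give 600 nM, within a range from 120 nM to 3000 nM. This estimate means an expected step of a 4.2-fold lower number from compound 3 to compound 4 (0.62 log units; beyond the scatter).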

Compound 4, inhibition constant: 120 nM
Compound 4: middle estimate off by 5.0-fold (0.70 log units), on the high side; measured number inside the range.
By their numbers in this assay, from the lowest: compound 4; then compounds 1 and 3 (each within the scatter of the next).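

In this assay, placing 1-(4-methoxybenzyl)ethyl on the carbonyl carbon in place of (2,3-dichlorophenoxy)methyl gives a 21-fold lower number from compound 3 to compound 4 (1.32 log units; beyond the scatter), and placing it there in place of ((naphthalen-2-yl)oxy)methyl gives a 17-fold lower number from compound 1 to compound 4 (1.22 log units; beyond the scatter). The earlier step, a 1.3-fold higher number from compound 1 to compound 3 (0.10 log units; within the scatter), only exchanged one aromatic group for another on the oxygen and left the two compounds indistinguishable, whereas these new steps show that the group on this carbonyl carbon can move the number far beyond the scatter. Compound 2 also lacks the oxygen and has a branched carbon on the carbonyl, but it cannot show whether the chlorines or the methoxy group matter on this kind of arm, given how far its numbers disagree: the several entries of compound 2 in this assay, 120 nM; 1600 nM (2 entries)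

The new group differs from the old ones in several ways at once, so the compounds shown do not separate the effect of losing the oxygen from that of adding the branch or of exchanging the chlorines for methoxy. On these data alone, it also remains open whether the methoxy group itself is needed, or whether an amine or a carboxylic acid at the same place on the aromatic ring would give a similar number.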